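The source may report more compounds than this note shows. Statements on the series, on what has been measured and on what is new or still open speak of the compounds shown alone.

Measured so far:
compound 1, `Brc1cn2ccnc2c(-c2ccc3ncn(C4CCCCC4)c3c2)n1` — 9.15%
compound 2, `c1ccc(-c2cn3ccnc3c(-c3ccc4ncn(C5CCCCC5)c4c3)n2)cc1` — 34.5%

In a functional assay on OVCAR-4 cells (Homo sapiens) for inhibition, read by sulforhodamine B assay, with a stated time of 48 h, tested at 10 uM (a higher number here means more inhibition at the concentration tested (going by the name of the read-out), a lower number less inhibition), compound 1 gives 9.15% and compound 2 gives 34.5%. For the measured compounds named here, compound 2 thus stands highest of the two numbers; its nearest neighbour is compound 1, and the one measured step, a number 25.4 percentage points higher from compound 1 to compound 2 (beyond the scatter), lies beyond the scatter.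

Compound 3, `COc1ccc(-c2cn3ccnc3c(-c3ccc4ncn(C5CCCCC5)c4c3)n2)cc1`, differs from compound 2 in one place: methoxy in place of hydrogen on an aromatic carbon. Going by the values given here, no measured step bears directly on this change. Among the compounds with values here, the single step of a number 25.4 percentage points higher from compound 1 to compound 2 (beyond the scatter) concerns a different exchange, phenyl for bromo, and says nothing about adding methoxy to a phenyl already present. Within the data shown here, with no comparable step in hand, the expectation is a step that stays within the usual scatter, in no preferred direction.

For compound 3 the estimated value is therefore 36%, with a range from 18% to 58%. For compound 3 this estimate means an expected step of a number 1.5 percentage points higher from compound 2 to compound 3 (within the scatter), within the scatter.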

Compound 3, a percentage reported as inhibition, at one concentration (the size of the read-out at that concentration, not a potency): 46.4%
The estimate for compound 3 lay 10.4 percentage points below the measured number, within the range that was stated.
By their numbers in this assay, from the lowest: compound 1; then compound 2; then compound 3.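

In this assay, the phenyl ring brought in for bromo proves to be a working point of change in its own right: methoxy in place of hydrogen, para to a large group, moves the read-out beyond the scatter (a number 11.9 percentage points higher from compound 2 to compound 3 (beyond the scatter)). The full exchange of bromo for 4-methoxyphenyl gives the largest step among these compounds (a number 37.3 percentage points higher from compound 1 to compound 3 (beyond the scatter)), so the gain seen with phenyl extends further once that ring carries a methoxy. No supporting data bear on why methoxy has this effect.

Going by these compounds, whether an amine, a carboxylic acid or a longer alkoxy chain in that same place would raise the number further remains open. On these data alone, these read-outs each come from a single concentration, so the potency of the compounds also remains open.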